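Replacing 4-cyanophenyl with 2,3,4-trimethoxyphenyl in compound 4

The compounds below may be only part of what the source reports. "The series", "measured", "known", "first", "only" and "open" are said of these compounds alone.

In a functional assay on A549 cells (Homo sapiens) for cytotoxicity, read by MTT assay, with a stated time of 72 h (a higher number here means a weaker inhibitor, a lower number a stronger inhibitor), compound 3 `N#Cc1ccc(/C=C/C(=O)Nc2cc3c(Nc4ccc(F)c(Cl)c4)ncnc3cc2O[C@H]2CCOC2)cc1` is recorded as "not active" (no number reported), so it has no single number. Compound 4 `COc1ccc(/C=C/C(=O)Nc2cc3c(Nc4ccc(F)c(Cl)c4)ncnc3cc2O[C@H]2CCOC2)c(OC)c1OC` keeps the shared core but changes one group: 2,3,4-trimethoxyphenyl in place of 4-cyanophenyl on a double-bonded chain carbon bound to a double-bonded chain carbon. With no number for compound 3, the size of this change cannot be calculated, so the closest guides are two compounds with methoxy-bearing groups at the same place. Compound 1 `COc1ccc(/C=C/C(=O)Nc2cc3c(Nc4ccc(F)c(Cl)c4)ncnc3cc2O[C@H]2CCOC2)c(OC)c1` gives 9350 nM, and compound 2 `COc1cc(/C=C/C(=O)Nc2cc3c(Nc4ccc(F)c(Cl)c4)ncnc3cc2O[C@H]2CCOC2)cc(OC)c1OC` gives 4150 nM. The step between them, a 2.3-fold lower number from compound 1 to compound 2 (0.35 log units; beyond the scatter), is modest. Compound 4 is therefore expected to give a measurable number close to these two values, rather than repeat the result for compound 3. The estimated value for compound 4 is 6000 nM, with an expected range from 2500 nM to 14000 nM.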

Compound 4, half-maximal inhibitory concentration: 70 nM
For compound 4 the middle estimate is 86-fold (1.93 log units) above the measured one; the measured number lies below the stated range.
By their numbers in this assay, from the lowest: compound 4; then compound 2; then compound 1.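

In this assay, for the compounds shown here, the arrangement of methoxy groups on this aromatic ring matters far more than the earlier compounds showed: 2,3,4-trimethoxyphenyl in place of 3,4,5-trimethoxyphenyl gives a 59-fold lower number from compound 2 to compound 4 (1.77 log units; beyond the scatter), although both groups have the same atoms. Methoxy in place of hydrogen on an aromatic carbon gives a 130-fold lower number from compound 1 to compound 4 (2.13 log units; beyond the scatter), so one added group can produce a large step. No measurement here explains these steps. Still open, from the compounds shown here alone, is whether methoxy itself is needed, or whether hydroxy or ethoxy groups on this ring would give similar numbers.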